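A vinylsulfonyl swap on a ring nitrogen

The source may hold more compounds than are shown below. What is called first, only, known or untested is meant among the compounds shown, and "the series" means these compounds.

In a functional assay on Hep 3B2 cells (Homo sapiens) for antiproliferative activity, with a stated time of 72 h (on this read-out lower numbers stand for stronger inhibition and higher numbers for weaker inhibition), compound 1 `CC#CC(=O)N1CCN(CCCn2cc(-c3cc(OC)cc(OC)c3)c3cnc(NC)nc32)CC1` gives > 10000 nM, which is a limit of the assay and not a number. For the measured compounds named here, of the two compounds measured so far, only compound 2 `C=CC(=O)Nc1cccc(C)c1Nc1ccc2c(C(=O)c3cc(OC)cc(OC)c3)c[nH]c2n1` gives an actual number, at 438 nM. Compound 2 differs from compound 1 in more than one place, so it offers little guidance on a single exchange.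

Compound 3 `C=CS(=O)(=O)N1CCN(CCCn2cc(-c3cc(OC)cc(OC)c3)c3cnc(NC)nc32)CC1` keeps the core of compound 1 and changes one group on an amine nitrogen in a ring, where vinylsulfonyl takes the place of (prop-1-yn-1-yl)carbonyl (vinylsulfonyl in place of (prop-1-yn-1-yl)carbonyl on an amine nitrogen in a ring). Going by the values given here, no measured pair shows what this exchange does. The closest guide is therefore compound 1 , which sits at the limit of > 10000 nM in this assay, at which 1 of the 2 values shown sits. With nothing pointing to a gain or a loss, the estimated change is a number no higher from compound 1 to compound 3 (the limit leaves the size open), which is expected to stay within the usual scatter. In this assay the expected value for compound 3 is 10000 nM, with an estimated range from 3000 nM to 20000 nM, and the assay may well report only a limit again.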

Compound 3, half-maximal inhibitory concentration: > 10000 nM
Compound 3 gave a limit, no number; the forecaster's own chance of this, stated with the estimate: 65%; the middle value lies on the limit itself.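

Compound 3, like compound 1, gives only a limit of the assay and not a number in this assay, so no step can be read between the two. From the compounds shown here alone, whether vinylsulfonyl in place of (prop-1-yn-1-yl)carbonyl on an amine nitrogen in a ring strengthens, weakens or leaves unchanged the inhibition stays open.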